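Ester chain change on the shared core: fluorophenylsulfanylethyl for nitrophenylsulfanyl

The source may hold more compounds than are shown below. What is called first, only, known or untested is meant among the compounds shown, and "the series" means these compounds.

Of the compounds shown here, three on a shared core have been measured in a functional assay on PC-3 cells (Homo sapiens) for inhibition, read by MTT assay, with a stated time of 48 h; on this read-out lower numbers stand for stronger inhibition and higher numbers for weaker inhibition. Compound 1 `C=C1CC[C@@H]2[C@](C)(CO)[C@H](O)CC[C@@]2(C)[C@@H]1CC(Sc1ccc(F)cc1)C1=CCOC1=O` gives 16000 nM. For the measured compounds named here, compound 2 `C=C1CC[C@@H]2[C@](C)(CO)[C@H](O)CC[C@@]2(C)[C@@H]1CC(Sc1ccc(OC)cc1)C1=CCOC1=O` gives 15000 nM, and the step of a 1.1-fold lower number from compound 1 to compound 2 (0.03 log units; within the scatter) is the only single-point comparison available. Compound 3 `C=C1CC[C@@H]2[C@](C)(CO)[C@H](O)CC[C@@]2(C)[C@@H]1C/C=C1/C(=O)OC[C@H]1OC(=O)CSc1ccc([N+](=O)[O-])cc1` gives 17000 nM; its number sits alongside those of compound 1 and compound 2, with gaps to each that are within the scatter, so the three compounds cannot be told apart on this read-out.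

Compound 4 `C=C1CC[C@@H]2[C@](C)(CO)[C@H](O)CC[C@@]2(C)[C@@H]1C/C=C1/C(=O)OC[C@H]1OC(=O)CCCSc1ccc(F)cc1` is not yet measured. Relative to compound 3 it carries 2-((4-fluorophenyl)sulfanyl)ethyl in place of (4-nitrophenyl)sulfanyl on a saturated chain carbon bound to a carbonyl carbon. Going by the values given here, the single measured step, from compound 1 to compound 2, concerns a substituent on the aromatic ring rather than the chain that is altered here, and it was within the scatter, so it bears on this change only loosely. With no step beyond the scatter anywhere among the three compounds, compound 4 is expected to show a 1.1-fold lower number from compound 3 to compound 4 (0.03 log units; within the scatter), that is, no change beyond the scatter. The estimate for compound 4 in this assay is therefore 16000 nM, within a range from 7000 nM to 36000 nM.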

Compound 4, half-maximal inhibitory concentration: 12000 nM
Estimate against measurement, compound 4: 1.3-fold (0.12 log units) above, within the range that was stated.
By their numbers in this assay, from the lowest: compounds 4, 2, 1 and 3 (each within the scatter of the next).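

In this assay the exchange on a saturated chain carbon bound to a carbonyl carbon gives a 1.4-fold lower number from compound 3 to compound 4 (0.15 log units; within the scatter), the first step read at this place in the ester chain. The chain and the ring substituent differ together here, since ((4-nitrophenyl)sulfanyl)methyl gives way to 3-((4-fluorophenyl)sulfanyl)propyl, and even this combined change stays within the scatter, which the earlier step on the aromatic ring alone could not show. No measured information is available to explain this result.

The compounds shown do not separate the contribution of the chain from that of the ring substituent. Going by these compounds, whether an amine, a carboxylic acid or a still longer chain at this place would move the number beyond the scatter remains open.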